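The compounds below may be only part of what the source reports. "The series", "measured", "known", "first", "only" and "open" are said of these compounds alone.

Measured in an assay on HEK293 cells for antagonist activity at P2X purinoceptor 7 (Homo sapiens), read by fluorescence, with stated times of 10 min and 20 min; on this read-out higher numbers stand for weaker inhibition and lower numbers for stronger inhibition:

compound 1 `CCCCCCCCCC(=O)OCc1cn(-c2ccc(Cl)cc2)nn1` — 108 nM
compound 2 `CCCCOCc1cn(-c2cc(Cl)ccc2Cl)nn1` — 621 nM
compound 3 `O/N=C/c1cnn(-c2ccccc2)n1` — 897 nM

Compound 3 gives the highest of the three numbers. Its nearest neighbour is compound 2, whose value sits within the usual scatter of that of compound 3, so the two cannot be told apart on these data. Compound 1 is furthest away, with a lower number that lies beyond the scatter relative to compound 3.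

The step from compound 3 to compound 4 `OCc1cnn(-c2ccccc2)n1` exchanges one small group on the shared core for another: a group of 2 heavy atoms (1 carbon, 1 oxygen; no ring) in place of a group of 3 heavy atoms (1 carbon, 1 nitrogen, 1 oxygen; no ring), on an aromatic carbon. The hydroxymethyl that enters keeps a hydrogen-bond donor and an acceptor, so the change is modest in size and in what is counted.

Among the compounds with values here, no measured pair differs in this way, so the size of the step has no direct precedent. The expectation is for a small step in this assay, with no clear direction, and most likely not beyond the scatter; compound 4 is estimated at 1200 nM, range 500 nM to 3000 nM. This corresponds to an estimated step of a 1.3-fold higher number from compound 3 to compound 4 (0.13 log units; within the scatter).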

Compound 4, half-maximal inhibitory concentration: 522 nM
Compound 4: middle estimate off by 2.3-fold (0.36 log units), on the high side; measured number inside the range.
By their numbers in this assay, from the lowest: compound 1; then compounds 4, 2 and 3 (each within the scatter of the next).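

In this assay, within the data shown here, placing hydroxymethyl on this aromatic carbon in exchange for the group of 3 heavy atoms gives a 1.7-fold lower number from compound 3 to compound 4 (0.24 log units; within the scatter) and provides the first pair that differs in one place. At this position, the double bond outside aromatic rings and the nitrogen of the leaving group can therefore be lost without a difference that can be told from the scatter, while the hydrogen-bond donor count stays the same and the acceptor count goes from 2 to 1. No evidence on the origin of this result is available.

From the compounds shown here alone, whether an amine, a carboxylic acid or a longer chain on this aromatic carbon would shift the number beyond the scatter remains open. Compound 1 and compound 2 differ from compound 4 in more than one place, so they give no reading on this position, and the same exchange on a differently substituted core also remains untested in the compounds shown.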